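Halogen Pattern on the Aniline Ring and Cell Toxicity

The source may hold more compounds than are shown below. What is called first, only, known or untested is meant among the compounds shown, and "the series" means these compounds.

Measured so far, in a functional assay on cells (Panel CNS (Carcinoma cell lines), Homo sapiens) for inhibition, read by sulforhodamine B assay, with a stated time of 48 h; on this read-out lower numbers stand for higher toxicity in this test and higher numbers for lower toxicity in this test:
compound 1 `CN1CCN(CCCOc2cccc3nc(Nc4ccc(Cl)c(C(F)(F)F)c4)ccc23)CC1` gives 6980 nM;
compound 2 `CN1CCN(CCCOc2cccc3nc(Nc4ccc(Cl)c(F)c4)ccc23)CC1` gives 6460 nM;
compound 3 `CN1CCN(CCCOc2cccc3nc(Nc4ccc(F)c(F)c4)ccc23)CC1` gives 16100 nM.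

Compound 3 stands highest of the three numbers in this assay, and both steps that reach it, a 2.3-fold higher number from compound 1 to compound 3 (0.36 log units; beyond the scatter) and a 2.5-fold higher number from compound 2 to compound 3 (0.40 log units; beyond the scatter), lie beyond the scatter; the step of a 1.1-fold lower number from compound 1 to compound 2 (0.03 log units; within the scatter) lies within it. Compound 4 `CN1CCN(CCCOc2cccc3nc(Nc4cc(Cl)cc(Cl)c4)ccc23)CC1` differs from compound 3 by 3,5-dichlorophenyl in place of 3,4-difluorophenyl on a nitrogen on an aromatic ring. Within the data shown here, the one measured step that bears on this change is a 2.5-fold higher number from compound 2 to compound 3 (0.40 log units; beyond the scatter), in which fluoro replaced chloro and the number rose. Reversing that direction, and with chlorine now at two positions, compound 4 is expected to show a modest downward step a 2.3-fold lower number from compound 3 to compound 4 (0.36 log units; beyond the scatter) in this assay. The estimate for compound 4 is therefore 7000 nM, with a range from 3000 nM to 16000 nM.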

Compound 4, concentration lethal to 50% of the cells: 6200 nM
For compound 4 the middle estimate is 1.1-fold (0.05 log units) above the measured one; measured number inside the range.
By their numbers in this assay, from the lowest: compounds 4, 2 and 1 (each within the scatter of the next); then compound 3.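

In this assay the change to 3,5-dichlorophenyl gives a 2.6-fold lower number from compound 3 to compound 4 (0.41 log units; beyond the scatter) and the comparisons a 1.0-fold lower number from compound 2 to compound 4 (0.02 log units; within the scatter) and a 1.1-fold lower number from compound 1 to compound 4 (0.05 log units; within the scatter) lie within the scatter. Among these compounds, on this nitrogen, two different chlorine-bearing rings and the trifluoromethyl-bearing ring therefore cannot be told apart, and only compound 3, the one compound without chlorine, stands apart. No evidence is at hand that gives a cause for this split. Left open is whether a plain phenyl, a 3,5-difluorophenyl or a 3-methoxyphenyl on this nitrogen would stand with compound 3 or with the others.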